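Adding a methoxy group to compound 2

The compounds below may be only part of what the source reports. "The series", "measured", "known", "first", "only" and "open" are said of these compounds alone.

Values in a functional assay on HCT-116 cells (Homo sapiens) for inhibition, read by sulforhodamine B assay, with a stated time of 48 h, tested at 50 uM (on this read-out lower numbers stand for less inhibition of growth and higher numbers for more inhibition of growth at the one concentration tested), follow
Compound 1 (`COc1ccc(/C=C/C(=O)/C=C/c2ccc(OCc3cn(CCCCCOc4cc(=O)oc5ccccc45)nn3)c(OC)c2)cc1OC`) gives 45%
Compound 2 (`COc1cc(/C=C/C(=O)/C=C/c2ccccc2)ccc1OCc1cn(CCCCOc2cc(=O)oc3ccccc23)nn1`) gives 34%

Compound 2 holds the lower of the two numbers at 34% and compound 1 reads higher at 45% by a gap beyond the scatter. These two compounds differ in more than one place, so that gap cannot be assigned to any single change.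

Compound 3 (`COc1ccc(/C=C/C(=O)/C=C/c2ccc(OCc3cn(CCCCOc4cc(=O)oc5ccccc45)nn3)c(OC)c2)cc1`) departs from compound 2 in one place (methoxy in place of hydrogen on an aromatic carbon), with methoxy in place of hydrogen on an aromatic carbon, turning phenyl to 4-methoxyphenyl. Within the data shown here, no measured pair shows this change alone. In this assay the estimated step of a number 4 percentage points higher from compound 2 to compound 3 (within the scatter) is expected to be small and upward, with none beyond the scatter. Compound 3 is estimated at 38% with an expected range from 26% to 50% in this measurement.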

Compound 3, percent growth inhibition at one concentration: 40%
For compound 3 the middle estimate is 2 percentage points below the measured one; low and high end bracket the measured number.
By their numbers in this assay, from the lowest: compounds 2, 3 and 1 (each within the scatter of the next, the first and the last beyond it).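

In this assay, among these compounds, the one pair that differs in a single place gives a number 6 percentage points higher from compound 2 to compound 3 (within the scatter). At this position, on an aromatic carbon para to a large group, turning phenyl to 4-methoxyphenyl therefore leaves percent growth inhibition within the usual scatter, so this single methoxy group shows no clear effect on the read-out. No supporting measurement bears on this result.

The compounds shown leave open whether an amine or a carboxylic acid in the same place would give a step beyond the scatter. They also do not show what any single change contributes in compound 1, which differs from compound 3 in more than one place.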